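The source may report more compounds than this note shows. Statements on the series, on what has been measured and on what is new or still open speak of the compounds shown alone.

Measured so far in an ADME assay on BHK-21 cells (Mesocricetus auratus) for cytotoxicity, read by MTT assay, with a stated time of 96 h; on this read-out lower numbers stand for higher toxicity in this test and higher numbers for lower toxicity in this test:
- compound 1 `COc1nc2ccc(CSc3ccccn3)cc2nc1OC`: > 100000 nM
- compound 2 `CCOC(=O)c1ccc(SCc2ccc3nc(OC)c(OC)nc3c2)cc1`: > 100000 nM

Both entries are limits of this assay, not numbers. Compound 2 stands at the limit > 100000 nM and nothing finer is known about it. Compound 1 likewise gives only the limit > 100000 nM. Going by the values given here, the series therefore shows no resolved step at all, only the fact described by the limit of > 100000 nM in this assay, at which 2 of the 2 values shown sit.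

Compound 3 `COc1nc2ccc(CSc3ccc(C(=O)O)cc3)cc2nc1OC` differs from compound 2 by hydrogen in place of ethyl on an oxygen next to a carbonyl group; read one bond further out, ethoxycarbonyl becomes carboxy. Among the compounds with values here, with no measured step to lean on, no movement beyond the usual scatter is expected in this assay in either direction. For compound 3 the estimate is 150000 nM (range 50000 nM to 500000 nM), most likely again reported only as a limit, which means an expected step that the limit leaves unreadable from compound 2 to compound 3.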

Compound 3, half-maximal cytotoxic concentration: 65000 nM
Beside the measured number, compound 3's estimate is 2.3-fold (0.36 log units) above it; the measured number falls inside the stated range.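

In this assay, going by these compounds alone, compound 3, with carboxy in place of ethoxycarbonyl, gives the first value that is a number and not a limit, which puts this position within the readable range of the test. Hydrogen in place of ethyl on an oxygen next to a carbonyl group gives an at least 1.5-fold lower number from compound 2 to compound 3 (0.18 log units; that floor lies within the scatter), so the change can be read only as a floor, and no lowering beyond the scatter is established. Going by these compounds, the true size of the step stays unknown because compound 2 is held only as a limit: the limit of > 100000 nM in this assay, at which 2 of the 3 values shown sit.

On these data alone, whether the readable value belongs to the carboxy group in particular, or would also appear with an amide or an amine in its place, stays open. As far as these compounds go, how a longer chain than ethyl on that oxygen, such as butyl, would read also stays open.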